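This account rests on a few compounds, and the source may have more. Where it says the series, first, only, none or still open, it means among the compounds named here.

Measured so far in an ADME assay on microsomes from liver (Homo sapiens) for metabolic stability, read by LC-MS, using NADPH, tested at 5 uM; on this read-out lower numbers stand for a shorter-lived compound and higher numbers for a longer-lived compound:
compound 1 `Cc1cccc(CSc2cc(Cl)c(C)cc2S(=O)(=O)/N=C(\N)n2nccc2-c2ccccc2)c1` gives 0.232 h
compound 2 `Cc1cc(-c2ccccc2)n(/C(N)=N/S(=O)(=O)c2cc(C)c(Cl)cc2SCc2ccc(C(F)(F)F)cc2)n1` gives 0.241 h
compound 3 `Cc1cccc(CSc2cc(Cl)c(C)cc2S(=O)(=O)/N=C(\N)n2nc(C)cc2-c2ccccc2)c1` gives 0.214 h

Compound 1 lies within the scatter of compound 2 and of compound 3; the three numbers cannot be told apart. Compound 4 `Cc1cc(S(=O)(=O)/N=C(\N)n2nccc2-c2ccccc2)c(SCc2cccc3ccccc23)cc1Cl` is to be measured in this assay. Its change from compound 1 is naphthalen-1-yl in place of 3-methylphenyl on a saturated chain carbon bound to a sulfur. The step that bears on it is the one at the same place, a 1.1-fold lower number from compound 2 to compound 3 (0.05 log units; within the scatter), an exchange of one aromatic group for another on a saturated chain carbon bound to a sulfur; a 1.1-fold lower number from compound 1 to compound 3 (0.04 log units; within the scatter) sits elsewhere. Within the data shown here, both stayed within the scatter, and no measured step moved beyond it. Compound 4 is therefore expected to show no step beyond the scatter, a 1.1-fold lower number from compound 1 to compound 4 (0.02 log units; within the scatter). The estimate for compound 4 is 0.22 h, with a range from 0.12 h to 0.4 h.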

Compound 4, half-life: 0.268 h
Compound 4: the middle estimate sits 1.2-fold (0.09 log units) below what was measured; the measured number falls inside the stated range.
By their numbers in this assay, from the lowest: compounds 3, 1, 2 and 4 (each within the scatter of the next).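

In this assay, naphthalen-1-yl in place of 3-methylphenyl on a saturated chain carbon bound to a sulfur gives a 1.2-fold higher number from compound 1 to compound 4 (0.06 log units; within the scatter) and so stays within the scatter. The earlier exchange at this place kept a single six-membered aromatic ring, whereas here a group of 2 such rings, with 10 heavy atoms against 7, is also read as no change. Nothing available accounts for this half-life.

Open, going by these compounds, is whether a group carrying an amine or a carboxylic acid at this place would move the number beyond the scatter. The same holds for a longer chain in place of the saturated chain carbon.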